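Quaternary ammonium in place of the carbamate on the shared core

The compounds below may be only part of what the source reports. "The series", "measured", "known", "first", "only" and "open" are said of these compounds alone.

Measured compounds:
- compound 1, `CCCC[C@]1(CC)CS(=O)(=O)c2ccc(-c3ccccc3)cc2[C@@H](c2cccc(OC)c2)[C@H]1O`: 180 nM
- compound 2, `CCCC[C@]1(CC)CS(=O)(=O)c2ccc(NC(=O)OCc3ccccc3)cc2[C@@H](c2ccccc2)[C@H]1O`: 400 nM
- compound 3, `CCC1(CC)CS(=O)(=O)c2ccc(N)cc2[C@@H](c2ccccc2)[C@H]1O`: 4000 nM

All three numbers come from an assay on cells for inhibition of ileal sodium/bile acid cotransporter (Homo sapiens); a lower number here means a stronger inhibitor, a higher number a weaker inhibitor. Compound 2 holds the second highest of the three values; its nearest neighbour is compound 1, which returns a lower number beyond the scatter, while compound 3 sits far above it, also beyond the scatter. Compound 3 differs from compound 2 in more than one place, so its value shows only that the free amine on a core with two ethyl chains gives the weakest number in the set.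

The unmeasured compound 4, `CCCC[C@]1(CC)CS(=O)(=O)c2ccc([N+](C)(C)C)cc2[C@@H](c2ccccc2)[C@H]1O`, differs from compound 2 in one place: a group of 4 heavy atoms (3 carbon, 1 nitrogen; no ring) in place of a group of 11 heavy atoms (8 carbon, 1 nitrogen, 2 oxygen; one six-membered aromatic ring of carbon only), on an aromatic carbon.

Within the data shown here, no measured pair shows this exchange. The only direct hint is that the largest substituents at this position, in compound 1 and compound 2, carry the lowest numbers, and the smallest, in compound 3, the highest. A rise in this assay is therefore expected on going from compound 2 to compound 4, of the order of a 3.8-fold higher number from compound 2 to compound 4 (0.57 log units; beyond the scatter). Compound 4 is accordingly estimated at 1500 nM, with a range from 300 nM to 8000 nM.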

Compound 4, half-maximal inhibitory concentration: 83 nM
Compound 4: middle estimate off by 18-fold (1.26 log units), on the high side; measured number outside the range, below it.
By their numbers in this assay, from the lowest: compound 4; then compound 1; then compound 2; then compound 3.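

In this assay, among these compounds, the exchange of the (benzyloxycarbonyl)amino group for the quaternary ammonium group gives the first reading at this aromatic carbon from a pair differing in one place: a 4.8-fold lower number from compound 2 to compound 4 (0.68 log units; beyond the scatter), beyond the scatter. The ring, the carbonyl and the hydrogen-bond donor of the leaving group are therefore not required for a low number on this core, and a group with a net charge of +1 and no hydrogen-bond donors or acceptors is accepted here. Within this pair the smaller group carries the lower number, so compound 4 goes against any reading that larger groups at this position give lower numbers, and no measurement on hand accounts for the step.

Among the compounds shown here, the single pair changes size and charge together, so their contributions stay unseparated; on the same core, an uncharged dimethylamino group or a simple primary amine would pull them apart. Also open, as far as these compounds go, is how the number responds to changes on the nitrogen itself, such as a benzyl group or a longer alkyl chain in place of one methyl group.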